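Trifluoromethoxy for methoxy on the aryl group of compound 2

A few compounds are considered here, and "the series" means these few. Any claim that something is new, unique, unknown or untested is made for them only; others in the source may bear on it.

Measured so far:
compound 1, `CC(=O)N(C)c1ccc2[nH]c(-c3n[nH]c4ccccc34)cc2n1`, 14800 nM
compound 2, `COc1ccc(S(=O)(=O)N(C)c2ccc3[nH]c(-c4n[nH]c5ccccc45)cc3n2)cc1`, 22400 nM

Both numbers come from a functional assay on HCT-116 cells (Homo sapiens) for antiproliferative activity, read by MTT assay, with a stated time of 72 h; a lower number here means a stronger inhibitor, a higher number a weaker inhibitor. Compound 2 has the higher of the two numbers, but compound 1 lies within the usual scatter of it, so the two values cannot be ordered; neither compound counts as the stronger inhibitor on what is known. Going by the values given here, no step between measured compounds is available in this small set.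

The next compound is compound 3, `CN(c1ccc2[nH]c(-c3n[nH]c4ccccc34)cc2n1)S(=O)(=O)c1ccc(OC(F)(F)F)cc1`. It differs from compound 2 in one place: trifluoromethyl in place of methyl on an oxygen on an aromatic ring. Read one bond further out, this is methoxy to trifluoromethoxy, or 4-methoxyphenyl to 4-(trifluoromethoxy)phenyl.

Among the compounds with values here, nothing among the measured compounds shows what this exchange does in this assay, so no direction is supported. The working expectation is that the step from compound 2 to compound 3, a 1.1-fold lower number from compound 2 to compound 3 (0.05 log units; within the scatter), stays inside the scatter. Compound 3 is therefore estimated at 20000 nM, with a range from 7000 nM to 55000 nM, given the weak starting point of compound 2 at 22400 nM.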

Compound 3, half-maximal inhibitory concentration: 6040 nM
Beside the measured number, compound 3's estimate is 3.3-fold (0.52 log units) above it, and the stated range ends above it.
By their numbers in this assay, from the lowest: compound 3; then compounds 1 and 2 (each within the scatter of the next).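

In this assay, going by these compounds alone, trifluoromethyl in place of methyl on an oxygen on an aromatic ring gives a 3.7-fold lower number from compound 2 to compound 3 (0.57 log units; beyond the scatter) and is the only single-place step so far, a modest one beyond the scatter. The group on this oxygen therefore affects the read-out, so 4-(trifluoromethoxy)phenyl and 4-methoxyphenyl are not interchangeable here, something the earlier values could not show. No measurement accompanies this step that could account for it, so it stands as an observation from one pair.

On these data alone, whether the lower number is specific to trifluoromethoxy remains open, since a chlorine, a nitrile or an amine at the same place on the ring could give a similar or a different result, and a longer chain such as ethoxy could fall on either side of the methoxy compound. As far as these compounds go, it is also open whether the same exchange would produce a step of similar size on an aryl group with a different ring or in a compound with a different group on the sulfonamide nitrogen.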